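Replacing methoxy with methyl on an aromatic carbon

The source may hold more compounds than are shown below. What is called first, only, known or untested is meant among the compounds shown, and "the series" means these compounds.

Measured so far in a functional assay on HeLa cells (Homo sapiens) for antiproliferative activity, read by MTT assay, with a stated time of 72 h; on this read-out lower numbers stand for stronger inhibition and higher numbers for weaker inhibition:
Compound 1 `Nc1nc(N)c2cc(CSC(=S)N3CCN(C4CCCCC4)CC3)ccc2n1` gives 5960 nM
Compound 2 `COc1ccc(N2CCN(C(=S)SCc3ccc4nc(N)nc(N)c4c3)CC2)cc1` gives 1660 nM

Within the data shown here, compound 2, at 1660 nM, holds the lower of the two numbers in this assay, and compound 1, at 5960 nM, is its only neighbour. Compound 3 `Cc1ccc(N2CCN(C(=S)SCc3ccc4nc(N)nc(N)c4c3)CC2)cc1` has methyl in place of methoxy on an aromatic carbon, para to a large group, a change from 4-methoxyphenyl to 4-methylphenyl (methyl in place of methoxy on an aromatic carbon). Among the measured compounds shown here, only one measured step bears on this change, and only loosely. It is a 3.6-fold lower number from compound 1 to compound 2 (0.56 log units; beyond the scatter), a modest move in which 4-methoxyphenyl takes the place of cyclohexyl on an amine nitrogen in a ring. That step replaces the whole group, whereas the new change leaves the aromatic ring in place and alters only what it carries. For the measured compounds named here, no measured pair compares methoxy with methyl directly, so the direction is open, and a shift beyond the scatter is not expected in this assay. The estimated step is a 1.2-fold higher number from compound 2 to compound 3 (0.08 log units; within the scatter), and it is only weakly supported. For compound 3 the expected value is 2000 nM, with an expected range from 800 nM to 4500 nM.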

Compound 3, half-maximal inhibitory concentration: 2130 nM
Estimate against measurement, compound 3: 1.1-fold (0.03 log units) below, within the range that was stated.
By their numbers in this assay, from the lowest: compounds 2 and 3 (each within the scatter of the next); then compound 1.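

In this assay, among these compounds, the first direct comparison at this aromatic carbon gives a 1.3-fold higher number from compound 2 to compound 3 (0.11 log units; within the scatter) for methyl in place of methoxy, so this change leaves compound 2 and compound 3 indistinguishable and the loss of the oxygen has no effect that can be read here. The advantage over cyclohexyl, until now seen only with 4-methoxyphenyl, also appears with 4-methylphenyl, at a 2.8-fold lower number from compound 1 to compound 3 (0.45 log units; beyond the scatter), and among these three compounds both aromatic groups on the ring nitrogen give lower numbers than cyclohexyl, with none going against that pattern. No supporting measurement bears on why methoxy and methyl read alike here.

As far as these compounds go, whether an amine or a carboxylic acid on the same aromatic carbon would also stay within the scatter of compound 2 remains open, as does the effect of a longer chain in place of methyl. With only methoxy and methyl compared here, these compounds do not show how much this position tolerates, nor whether the match between compound 2 and compound 3 would hold in any other test.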